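Amino group shift from compound 2 to compound 4

This account rests on a few compounds, and the source may have more. Where it says the series, first, only, none or still open, it means among the compounds named here.

- compound 1 `C[C@H](NC(=O)c1cccc(F)c1)c1ccc(NC(=O)N2CC(c3ccc(N)nc3)C2)cc1` gives 27 nM
- compound 2 `C[C@H](NC(=O)c1ncccn1)c1ccc(NC(=O)N2CC(c3ccc(N)nc3)C2)cc1` gives 160 nM
- compound 3 `C[C@H](NC(=O)C1CCOCC1)c1ccc(NC(=O)N2CC(c3ccc(N)nc3)C2)cc1` gives 110 nM

In a functional assay on COR-L23 cells (Homo sapiens) for antiproliferative activity, read by CellTiter-Glo, with a stated time of 72 h (a lower number here means a stronger inhibitor, a higher number a weaker inhibitor), compound 2 gives 160 nM and has two measured neighbours (a 1.5-fold lower number from compound 2 to compound 3 (0.16 log units; within the scatter); a 5.9-fold higher number from compound 1 to compound 2 (0.77 log units; beyond the scatter)). Compound 4 `C[C@H](NC(=O)c1ncccn1)c1ccc(NC(=O)N2CC(c3cncc(N)c3)C2)cc1` changes one group (5-aminopyridin-3-yl in place of 6-aminopyridin-3-yl on a saturated ring carbon): 5-aminopyridin-3-yl in place of 6-aminopyridin-3-yl on a saturated ring carbon. Among the measured compounds shown here, no measured step touches this group. The available steps change the group on a carbonyl carbon, and those beyond the scatter (a 5.9-fold higher number from compound 1 to compound 2 (0.77 log units; beyond the scatter); a 4.1-fold higher number from compound 1 to compound 3 (0.61 log units; beyond the scatter)) serve only as a guide to size. The expected step is similarly modest and upward (a 2.2-fold higher number from compound 2 to compound 4 (0.34 log units; beyond the scatter)), though no measurement fixes its direction. In this assay compound 4 is estimated at 350 nM (range 80 nM to 1500 nM).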

Compound 4, half-maximal inhibitory concentration: 1380 nM
For compound 4 the middle estimate is 3.9-fold (0.60 log units) below the measured one; measured number inside the range.
By their numbers in this assay, from the lowest: compound 1; then compounds 3 and 2 (each within the scatter of the next); then compound 4.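

In this assay, among the compounds shown here, the shift of the amino group gives an 8.6-fold higher number from compound 2 to compound 4 (0.94 log units; beyond the scatter), the first reading at this position on a saturated ring carbon of the four-membered ring, as the earlier steps all changed the group on a carbonyl carbon. Activity here therefore depends on where the amine sits on the pyridine, even though the two groups have the same atoms and the same counted donors and acceptors. No available evidence accounts for the size of this step.

From the compounds shown here alone, whether 5-aminopyridin-3-yl has a similar effect alongside the 3-fluorophenyl of compound 1 or the oxan-4-yl of compound 3 remains open. So does the outcome with a plain pyridin-3-yl or with a hydroxyl in place of the amine.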